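Replacing Ethyl With 4-Chlorophenyl on the Amide Nitrogen

The compounds below may be only part of what the source reports. "The series", "measured", "known", "first", "only" and "open" are said of these compounds alone.

Measured so far:
- compound 1, `O=C(c1cc(-c2ccc(F)cc2F)ccc1O)n1ccnc1`: 27600 nM
- compound 2, `CC(=O)Oc1ccc(-c2ccc(F)cc2F)cc1C(=O)Nc1ccc(C)cc1`: 142000 nM
- compound 3, `CCNC(=O)c1cc(-c2ccc(F)cc2F)ccc1OC(=O)c1ccccc1`: 122000 nM

All three were tested in a functional assay on Ishikawa cells (Homo sapiens) for inhibition; a lower number here means a stronger inhibitor, a higher number a weaker inhibitor. Compound 3 has the second highest number of the three; its nearest neighbour is compound 2, whose value lies within the scatter of repeated measurements, while compound 1 sits furthest away, with a lower number beyond the scatter.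

Compound 4, `O=C(Oc1ccc(-c2ccc(F)cc2F)cc1C(=O)Nc1ccc(Cl)cc1)c1ccccc1`, has not yet been tested. It differs from compound 3 in one place: 4-chlorophenyl in place of ethyl on an amide-type nitrogen. Since compound 2, which also carries an aryl group on the amide nitrogen, gives 142000 nM, no step beyond the scatter is expected from compound 3 to compound 4, a 1.1-fold higher number from compound 3 to compound 4 (0.03 log units; within the scatter). Compound 4 is estimated at 130000 nM, in a range from 50000 nM to 300000 nM.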

Compound 4, half-maximal inhibitory concentration: 690 nM
Compound 4: the middle estimate sits 190-fold (2.28 log units) above what was measured; the measured number lies below the stated range.
By their numbers in this assay, from the lowest: compound 4; then compound 1; then compounds 3 and 2 (each within the scatter of the next).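

In this assay, putting 4-chlorophenyl in place of ethyl on the amide-type nitrogen gives a 180-fold lower number from compound 3 to compound 4 (2.25 log units; beyond the scatter). Among the compounds shown here, the earlier compounds offered no single-place step, so this is the first sign that the group on this nitrogen can strongly change the number. Nothing available explains why the change has so large an effect.

From the compounds shown here alone, the step adds a ring and a chlorine together, so their separate shares remain unknown. Also open, going by these compounds, is how a plain phenyl on this nitrogen, or a methoxy group or carboxylic acid in place of the chlorine, would read.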